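This account rests on a few compounds, and the source may have more. Where it says the series, first, only, none or still open, it means among the compounds named here.

Compound 1 `O=C1C=C(Nc2ccc(I)cc2)C(=O)c2c1nc1n2[C@H]2OC[C@@H](O)[C@H]2OC1` is the starting point. Among the compounds with values here, in a functional assay on MGC-803 cells (Homo sapiens) for inhibition, read by sulforhodamine B assay (a lower number here means a stronger inhibitor, a higher number a weaker inhibitor), compound 1 gives 1400 nM, which is the only plain number among the three values shown. Compound 2 `O=C1C(NC2CC2)=CC(=O)c2c1nc1n2[C@H]2OC[C@@H](O)[C@H]2OC1` reaches only a limit of the assay, > 4000 nM. Compound 3 `O=C1C(NC2CCCC2)=CC(=O)c2c1nc1n2[C@H]2OC[C@@H](O)[C@H]2OC1` likewise reaches only a limit of the assay, > 16000 nM. Within the data shown here, the single measured step, a step that the two limits leave unreadable from compound 2 to compound 3, therefore has no readable size. Both of its ends sit at limits, one being the limit of > 4000 nM in this assay, at which 1 of the 3 values shown sits, and the other (the limit of > 16000 nM in this assay, at which 1 of the 3 values shown sits).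

Compound 4 `O=C1C=C(Nc2ccc(C(F)(F)F)cc2)C(=O)c2c1nc1n2[C@H]2OC[C@@H](O)[C@H]2OC1` has not been measured. It differs from compound 1 in one place: trifluoromethyl in place of iodo on an aromatic carbon. The measured step touches a different part of the shared core and, being unreadable, offers neither direction nor size, so nothing measured here speaks to the change from compound 1 to compound 4. The expectation is therefore a step that stays within the usual scatter. Compound 4 is expected to give about 1500 nM in this assay, with a likely range from 500 nM to 5000 nM. That estimate corresponds to an expected step of a 1.1-fold higher number from compound 1 to compound 4 (0.03 log units; within the scatter).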

Compound 4, half-maximal inhibitory concentration: 2820 nM
Estimate against measurement, compound 4: 1.9-fold (0.27 log units) below; the measured number falls inside the stated range.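

Within the data shown here, the step from iodo to trifluoromethyl is the first in this set with a readable size, since the only earlier step cannot be read, and in this assay it is a 2.0-fold higher number from compound 1 to compound 4 (0.30 log units; within the scatter). At this place on the six-membered aromatic ring, then, iodo with its single heavy atom and trifluoromethyl with 4 heavy atoms cannot be told apart in this assay, and the pair gives the first sign that the position tolerates this one exchange without a change beyond the usual scatter of repeated measurements. None of the information at hand bears on why these two groups read alike, and this single pair says nothing about other groups at this place or about other parts of the molecule.

The compounds shown leave open what a group of a different kind at this place would do, such as a carboxylic acid, an amine or a longer alkyl chain, and whether any of them would give a step beyond the scatter. They also leave open what plain hydrogen in place of iodo would give, which would show whether this position needs a substituent at all.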